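The source may report more compounds than this note shows. Statements on the series, on what has been measured and on what is new or still open speak of the compounds shown alone.

Measured so far in a functional assay on MDA-MB-231 cells (Homo sapiens) for cytotoxicity, read by MTT assay, with a stated time of 24 h; a lower number here means a stronger inhibitor, a higher number a weaker inhibitor
- compound 1 `COc1ccc(/C=C2\CN(Cc3cn(Cc4cccc(Cl)c4)nn3)C/C(=C\c3ccc(OC)cc3)C2=O)cc1` gives 98000 nM
- compound 2 `COc1ccc(/C=C2\CN(C(=S)SCc3cn(Cc4ccc(F)cc4)nn3)C/C(=C\c3ccc(OC)cc3)C2=O)cc1` gives > 100000 nM (a limit, not a number)
- compound 3 `O=C1/C(=C/c2ccccc2F)CN(C(=S)SCc2cn(Cc3ccc(F)cc3)nn2)C/C1=C\c1ccccc1F` gives 58800 nM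

Compound 2 stands at > 100000 nM and this is a limit of the assay, not a number. Compound 4 `COc1ccc(/C=C2\CN(C(=S)SCc3cn(Cc4ccccc4Cl)nn3)C/C(=C\c3ccc(OC)cc3)C2=O)cc1` differs from compound 2 in one place (2-chlorophenyl in place of 4-fluorophenyl on a saturated chain carbon bound to an aromatic nitrogen), with 2-chlorophenyl in place of 4-fluorophenyl on a saturated chain carbon bound to an aromatic nitrogen. Within the data shown here, no measured pair isolates this change. The expectation therefore rests on the general level of the series, where compound 1 gives 98000 nM and compound 3 gives 58800 nM as numbers in the same high range. In this assay no step beyond the scatter is expected, in either direction. The estimated outcome is an at least 1.1-fold lower number from compound 2 to compound 4 (0.07 log units; that floor lies within the scatter) and it is expected to stay small. For compound 4 the expected value is 85000 nM (estimated range 35000 nM to 170000 nM) and the reading may well return only a limit.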

Compound 4, half-maximal inhibitory concentration: > 100000 nM
Compound 4 ended at the assay's limit; the forecaster's own chance of this, stated with the estimate: 45%; at least 1.1-fold (0.07 log units) between middle value and limit.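

In this assay compound 4 gives > 100000 nM as a limit and not a number. Among these compounds, compound 2 also stands at a limit, and no step between the two compounds can be read. As far as these compounds go, whether 2-chlorophenyl in place of 4-fluorophenyl shifts the read-out at all remains open.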